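This account rests on a few compounds, and the source may have more. Where it says the series, first, only, none or still open, it means among the compounds named here.

Working notes on the series, cytotoxicity arm.

Three compounds carry the shared core with the trifluorophenyl urea or amide: compound 1 `CC1CN(C(=O)Nc2cc(F)c(F)c(F)c2)Cc2c(N3CC(C#N)CC3=O)cnn21`, compound 2 `O=C1CC(c2cnc(C(F)(F)F)s2)CN1c1cnn2c1CN(C(=O)Nc1cc(F)c(F)c(F)c1)C(C1CC1)C2` and compound 3 `C[C@H]1Cn2ncc(N3CC(c4ccccc4)CC3=O)c2CN1CC(=O)Nc1cc(F)c(F)c(F)c1`. In a toxicity assay on HepG2 2.2.15 cells (Homo sapiens) for cytotoxicity, read by CellTiter-Glo (a higher number here means that more compound is tolerated, a lower number that less compound is tolerated), compound 1 gives 115000 nM. In this assay compound 2 gives 38500 nM. Compound 3 is recorded only as a limit in this assay, > 2000 nM, and the limit stands as noted in the limit of > 2000 nM in this assay, at which 1 of the 3 values shown sits. Of the two numbers in this assay compound 2 has the lower one, compound 1 sitting beyond the scatter above it.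

Compound 4 `Cc1nc(C2CC(=O)N(c3cnn4c3CN(C(=O)Nc3cc(F)c(F)c(F)c3)C(C3CC3)C4)C2)no1` is the next member to be run in this assay. It differs from compound 2 in one place: 5-methyl-1,2,4-oxadiazol-3-yl in place of 2-(trifluoromethyl)-1,3-thiazol-5-yl on a saturated ring carbon. Within the data shown here, no measured pair in the set isolates this exchange, so the expected step from compound 2 to compound 4 in this assay, a 1.2-fold higher number from compound 2 to compound 4 (0.07 log units; within the scatter), is taken as small, within the usual scatter, with no direction claimed. On that basis compound 4 is estimated at 45000 nM in this assay, with a plausible range from 18000 nM to 120000 nM.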

Compound 4, half-maximal cytotoxic concentration: > 200000 nM
Compound 4: only a limit was reported; the forecaster's own chance of this, stated with the estimate: 25%; middle value at least 4.4-fold (0.64 log units) from the limit.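

In this assay, 5-methyl-1,2,4-oxadiazol-3-yl in place of 2-(trifluoromethyl)-1,3-thiazol-5-yl on the saturated ring carbon gives an at least 5.1-fold higher number from compound 2 to compound 4 (0.71 log units; beyond the scatter). Among these compounds, this is the only step in the set that isolates this position, and it shows that the group held there can move the tolerated concentration beyond the scatter, which the earlier compounds, differing in more than one place, could not show. The value of compound 4 is a limit, not a number: the limit of > 200000 nM in this assay, at which 1 of the 4 values shown sits.

The exchange changes both the five-membered aromatic ring and its substituent, so the compounds shown do not separate the part played by the trifluoromethyl from that of the ring, and they give no cause for the step. On these data alone, whether an unsubstituted 1,3-thiazol-5-yl or a primary amine on this carbon would track with compound 2 or with compound 4 stays open.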